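Thiophene swap on the guanidine-bearing series: notes

This account rests on a few compounds, and the source may have more. Where it says the series, first, only, none or still open, it means among the compounds named here.

Values in a functional assay on cells (Cancer cell lines, Homo sapiens) for inhibition; on this read-out higher numbers stand for weaker inhibition of growth and lower numbers for stronger inhibition of growth:
compound 1 `Cc1cc(-c2nc3sc(C)cn3c2/C=N/NC(=N)N)c(C)s1` gives 18200 nM
compound 2 `N=C(N)N/N=C/c1c(-c2cc(Cl)sc2Cl)nc2n1CCS2` gives 17400 nM
compound 3 `Cc1cc(-c2nc3sccn3c2/C=N/NC(=N)N)c(C)s1` gives 30200 nM

Compound 1 sits among these three values, and both compound 2 and compound 3 lie within the scatter of it, so no ranking can be drawn from them.

The next entry is compound 4 `Cc1cn2c(/C=N/NC(=N)N)c(-c3cccs3)nc2s1`, and the change from compound 1 is thiophen-2-yl in place of 2,5-dimethylthiophen-3-yl on an aromatic carbon. Going by the values given here, no measured pair changes this group on its own, so direct evidence is lacking. Among the compounds with values here, the only measured step, a 1.7-fold higher number from compound 1 to compound 3 (0.22 log units; within the scatter), is at another place on the core and stays within the scatter. It bears only indirectly, as a sign that removing a methyl need not move the number in this assay. A small rise at most is therefore expected, with nothing beyond the scatter. The expected step is a 1.3-fold higher number from compound 1 to compound 4 (0.12 log units; within the scatter). For compound 4 the estimated value is 24000 nM, with an expected range from 11000 nM to 55000 nM.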

Compound 4, concentration for total growth inhibition: 11700 nM
Compound 4: middle estimate off by 2.1-fold (0.31 log units), on the high side, and the stated range covers the measured number.
By their numbers in this assay, from the lowest: compounds 4, 2, 1 and 3 (each within the scatter of the next, the first and the last beyond it).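

In this assay, going by these compounds alone, the swap of 2,5-dimethylthiophen-3-yl for thiophen-2-yl gives a 1.6-fold lower number from compound 1 to compound 4 (0.19 log units; within the scatter) and is the first step read at this position, since compound 1 and compound 3 carry the same group there. The group can therefore lose two heavy atoms, going from 7 to 5, without a step beyond the scatter, and an unsubstituted thiophen-2-yl serves as well as the dimethylated ring in this pair. No supporting data bear on why the number stays within the scatter.

Open, going by these compounds, is whether a larger change on this aromatic carbon would move the number beyond the scatter, for example a phenyl ring or a thiophene bearing an amine or a carboxylic acid. A single step also leaves open how the 2,5-dimethyl pattern and the attachment point of the thiophene each contribute, since both differ in this swap.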